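Urea-to-amide switch in the pyrazole urea series

The source may report more compounds than this note shows. Statements on the series, on what has been measured and on what is new or still open speak of the compounds shown alone.

Compound 2 `COc1cc(Cl)cc(-c2nn(-c3cccc(NC(=O)Nc4ccc(Cl)c(C(F)(F)F)c4)c3)cc2-c2ccncc2)c1` gives 79% in a functional assay on Malme-3M cells (Homo sapiens) for inhibition, read by sulforhodamine B assay, with a stated time of 48 h, tested at 0.1 uM; on this read-out lower numbers stand for a stronger effect and higher numbers for a weaker effect at the one concentration tested. It holds the lowest of the three numbers measured, though its neighbours lie within the scatter: compound 1 `O=C(Nc1cccc(-n2cc(-c3ccncc3)c(-c3cc(O)cc(Cl)c3)n2)c1)Nc1ccc(Cl)c(C(F)(F)F)c1` gives 81%, and compound 3 `COc1cc(Cl)cc(-c2nn(-c3cccc(NC(=O)Nc4cc(C(F)(F)F)cc(C(F)(F)F)c4)c3)cc2-c2ccncc2)c1` gives 87%. Within the data shown here, the only step measured in one place, a number 2 percentage points lower from compound 1 to compound 2 (within the scatter), concerns a different part of the molecule and does not bear on what follows. Compound 4 `COc1cc(Cl)cc(-c2nn(-c3cccc(NC(=O)c4cccc(C(F)(F)F)c4)c3)cc2-c2ccncc2)c1` differs from compound 2 by 3-(trifluoromethyl)phenyl in place of (4-chloro-3-(trifluoromethyl)phenyl)amino on a carbonyl carbon. Among the measured compounds shown here, no measured pair tests a change of this kind, so the direction of any step is unknown. With nothing beyond the scatter shown anywhere in this set, compound 4 is expected near the measured values, at 88% (range 72% to 102%), an expected step of a number 9 percentage points higher from compound 2 to compound 4 (within the scatter).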

Compound 4, a percentage reported as activity, at one concentration (the size of the read-out at that concentration, not a potency): 90%
Beside the measured number, compound 4's estimate is 2 percentage points below it; measured number inside the range.
By their numbers in this assay, from the lowest: compounds 2, 1, 3 and 4 (each within the scatter of the next, the first and the last beyond it).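

Among these compounds, at the carbonyl carbon, this change gives the first step beyond the scatter in this assay (a number 11 percentage points higher from compound 2 to compound 4 (beyond the scatter)), a modest weakening at the one concentration tested. The change removes the amino nitrogen and the chlorine together, so the step cannot be assigned to either one alone. No measurement here accounts for the step.

Which of the two losses carries the step stays open. So does the effect of a cyclohexyl group or a carboxylic acid on this carbonyl carbon.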